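Side-chain change on compound 3: working notes

This account rests on a few compounds, and the source may have more. Where it says the series, first, only, none or still open, it means among the compounds named here.

- compound 1 `COc1ccc2cc(-c3ccccc3)c(O)nc2c1`: 10000 nM
- compound 2 `COc1cc(OC)c2cc(-c3ccccc3)c(O)nc2c1`: 10000 nM
- compound 3 `CCOC(=O)Cn1c(=O)c(-c2ccc(OC)cc2)cc2c(OC)cc(OC)cc21`: 10000 nM

All three values come from a functional assay on T-24 cells (Homo sapiens) for cytotoxicity, read by colorimetric assay and MTT assay (on this read-out lower numbers stand for stronger inhibition and higher numbers for weaker inhibition), where compound 3 stands level with compound 1 and compound 2. The next compound is compound 4 `COc1ccc(-c2cc3c(OC)cc(OC)cc3n(CC#N)c2=O)cc1`, with cyano in place of ethoxycarbonyl on a saturated chain carbon bound to an aromatic nitrogen. Within the data shown here, no measured step covers this change. The only one, methoxy in place of hydrogen on an aromatic carbon, gave no change at the digits printed from compound 1 to compound 2 (within the scatter), so it offers weak, indirect support for a flat series. In this assay, the expected outcome is no change at the digits printed from compound 3 to compound 4 (within the scatter), with no shift expected beyond the scatter. For compound 4 the estimated value is 10000 nM, with an expected range of 3000 nM to 15000 nM.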

Compound 4, half-maximal inhibitory concentration: 10000 nM
Compound 4: the middle estimate sits on the measured number at the digits printed; low and high end bracket the measured number.
By their numbers in this assay, from the lowest: compounds 1, 2, 3 and 4 (each within the scatter of the next).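

Among these compounds, the first step at this position, cyano in place of ethoxycarbonyl on a saturated chain carbon bound to an aromatic nitrogen, gives no change at the digits printed from compound 3 to compound 4 (within the scatter) in this assay. The earlier step covered only an aromatic carbon, so the side chain is now shown to take a swap from 5 heavy atoms to 2 with no shift beyond the scatter. No measured data bear on why the number holds.

On these data alone, whether a carboxylic acid, an amine or a longer chain at this place would leave this level stays open. With all four compounds level, the series still gives no direction for improvement.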